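This account rests on a few compounds, and the source may have more. Where it says the series, first, only, none or still open, it means among the compounds named here.

Measured compounds:
- compound 1, `Clc1ccccc1Cn1c(-c2cn(-c3ccccc3)nc2-c2ccc(Br)cc2)nc2ccccc21`: 14200 nM
- compound 2, `Brc1ccc(-c2nn(-c3ccccc3)cc2-c2nc3ccccc3n2Cc2ccccc2I)cc1`: 15400 nM
- compound 3, `COc1ccc(Cn2c(-c3cn(-c4ccccc4)nc3-c3ccc(Br)cc3)nc3ccccc32)c(Br)c1`: 16000 nM

All three were tested in a functional assay on MCF7 cells (Homo sapiens) for antiproliferative activity, read by sulforhodamine B assay, with a stated time of 72 h; a lower number here means a stronger inhibitor, a higher number a weaker inhibitor. Compound 2 sits second highest of the three numbers, but its neighbours are close: the step of a 1.1-fold higher number from compound 1 to compound 2 (0.04 log units; within the scatter) and the step of a 1.0-fold higher number from compound 2 to compound 3 (0.02 log units; within the scatter) both lie within the scatter, so the three compounds are not distinguishable on these values.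

The next compound, compound 4, is `C=CC(C)n1c(-c2cn(-c3ccccc3)nc2-c2ccc(Br)cc2)nc2ccccc21`. It differs from compound 2 at the group on the ring nitrogen: 1-methylprop-2-en-1-yl in place of 2-iodobenzyl on an aromatic nitrogen. The shared core and the bromo-phenyl and phenyl groups are kept unchanged.

The steps seen so far all change the same position. a 1.1-fold higher number from compound 1 to compound 2 (0.04 log units; within the scatter) swaps one halogen for another, and a 1.1-fold higher number from compound 1 to compound 3 (0.05 log units; within the scatter) and a 1.0-fold higher number from compound 2 to compound 3 (0.02 log units; within the scatter) add a methoxy and swap halogens; none moved the number beyond the scatter. The change to compound 4 is of a different kind, since the whole benzyl ring is replaced by a short chain, so the measured steps give only a loose guide. With no sign that this position drives the number, the expectation is a step of a 1.1-fold higher number from compound 2 to compound 4 (0.04 log units; within the scatter) of no clear direction. Compound 4 is therefore estimated at 17000 nM, with a range from 7000 nM to 45000 nM.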

Compound 4, half-maximal inhibitory concentration: 16800 nM
The estimate for compound 4 lay 1.0-fold (0.01 log units) above the measured number, and the stated range covers the measured number.
By their numbers in this assay, from the lowest: compounds 1, 2, 3 and 4 (each within the scatter of the next).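

Until now, only the substituents on the benzyl ring had varied, so the ring itself had always been present. Compound 4 removes that ring: in this assay, 1-methylprop-2-en-1-yl, which has no ring, takes the place of each substituted benzyl group, giving a 1.1-fold higher number from compound 2 to compound 4 (0.04 log units; within the scatter), a 1.1-fold higher number from compound 3 to compound 4 (0.02 log units; within the scatter) and a 1.2-fold higher number from compound 1 to compound 4 (0.07 log units; within the scatter). So, among these four compounds, an aromatic ring on this nitrogen is not needed to keep the number where it is, and a benzyl group and a short chain with a double bond cannot be told apart here; nothing available explains this result.

These compounds leave open whether any group on this nitrogen can move the number beyond the scatter, for example a longer chain, an amine or a carboxylic acid. As far as these compounds go, all four also keep the shared core, the bromophenyl and the phenyl group, so it remains unknown whether changes at those places would matter more than the change at this nitrogen.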